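Chloro for hydrogen on the outer ring of compound 3

The source may hold more compounds than are shown below. What is called first, only, known or untested is meant among the compounds shown, and "the series" means these compounds.

Of the compounds shown here, three share one core and have been tested in an assay on HL-60 cells for inhibition of glutathione S-transferase P (Homo sapiens); a higher number here means a weaker inhibitor, a lower number a stronger inhibitor. Compound 1 `C=C(C)C(=O)c1ccc(OCc2nc(-c3ccc(O)cc3)no2)c(C)c1C` gives 3400 nM. Compound 2 `C=C(C)C(=O)c1ccc(OCc2nc(-c3ccc(Cl)cc3)no2)c(C)c1C` gives 2000 nM. Compound 3 `C=C(CC)C(=O)c1ccc(OCc2nc(-c3ccccc3)no2)c(Cl)c1Cl` gives 3600 nM. Compound 3 thus differs from compound 1 and from compound 2 only within the scatter of this assay, so the three numbers cannot be told apart with confidence.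

Compound 4 `C=C(CC)C(=O)c1ccc(OCc2nc(-c3ccc(Cl)cc3)no2)c(Cl)c1Cl` has not yet been measured. It differs from compound 3 by chloro in place of hydrogen on an aromatic carbon, sitting para to a large group; seen one bond further out, the change reads phenyl to 4-chlorophenyl.

Among the measured compounds shown here, only one measured step touches on this change: a 1.7-fold lower number from compound 1 to compound 2 (0.23 log units; within the scatter), where chloro replaced hydroxy rather than hydrogen on that same ring position. Since that step stayed within the scatter, a chloro entering this position is expected to move the number little, if at all, with at most a slight drift towards a lower value.

Compound 4 is therefore estimated at 2500 nM in this assay, with a range from 1000 nM to 6000 nM, which corresponds to an expected step of a 1.4-fold lower number from compound 3 to compound 4 (0.16 log units; within the scatter).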

Compound 4, half-maximal inhibitory concentration: 5400 nM
Compound 4: middle estimate off by 2.2-fold (0.33 log units), on the low side; measured number inside the range.
By their numbers in this assay, from the lowest: compounds 2, 1, 3 and 4 (each within the scatter of the next, the first and the last beyond it).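

In this assay, chloro in place of hydrogen at this position gives a 1.5-fold higher number from compound 3 to compound 4 (0.18 log units; within the scatter), so on the dichloro core of compound 3 the added chlorine leaves no change that can be told from the scatter. Among the compounds shown here, this is the first direct view of chloro replacing hydrogen here, and it adds to a 1.7-fold lower number from compound 1 to compound 2 (0.23 log units; within the scatter), where chloro replaced hydroxy on the dimethyl core of compound 1; the two steps are printed in opposite directions, but since both lie within the scatter, they show no real difference and no trend, only that a chloro on this ring position was accommodated without a clear shift in either of these two pairs. Nothing shown explains why these steps are so small.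

The compounds shown leave open whether a group of another kind at this same position, such as an amine, a carboxylic acid or a methoxy group, would move the number beyond the scatter. For the compounds shown here, they also leave open how chloro in place of hydrogen would behave on the dimethyl core, since no compound there carries a plain phenyl for comparison.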